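Compound 3 to compound 4: side-chain exchange

A few compounds are considered here, and "the series" means these few. Any claim that something is new, unique, unknown or untested is made for them only; others in the source may bear on it.

In an ADME assay on L6 cells (Rattus norvegicus) for cytotoxicity, read by resazurin assay, with a stated time of 72 h (on this read-out higher numbers stand for weaker inhibition and lower numbers for stronger inhibition), compound 1 (`CN1CCN(CCC(=O)NC2CC3(N4CCCCC4)CC(c4ccccc4)C2C(c2ccccc2)C3)CC1`) reads 61100 nM and compound 2 (`NC1CC2(N3CCCCC3)CC(c3ccccc3)C1C(c1ccccc1)C2`) reads 35000 nM while compound 3 (`CN1CCN(CC(=O)NC2CC3(N4CCCCC4)CC(c4ccccc4)C2C(c2ccccc2)C3)CC1`) reads 57500 nM in the same test. All three lie within the scatter of one another (a 1.7-fold lower number from compound 1 to compound 2 (0.24 log units; within the scatter)) (a 1.1-fold lower number from compound 1 to compound 3 (0.03 log units; within the scatter)) (a 1.6-fold higher number from compound 2 to compound 3 (0.22 log units; within the scatter)), so compound 3 holds no separate place. Compound 4 (`O=C(CN1CCCC1)OC1CC2(N3CCCCC3)CC(c3ccccc3)C1C(c1ccccc1)C2`) has (((pyrrolidin-1-yl)methyl)carbonyl)oxy in place of (((4-methylpiperazin-1-yl)methyl)carbonyl)amino on a saturated ring carbon. Among the compounds with values here, no measured step covers this exact exchange, but neither removing the side chain (a 1.7-fold lower number from compound 1 to compound 2 (0.24 log units; within the scatter)) nor shortening it (a 1.1-fold lower number from compound 1 to compound 3 (0.03 log units; within the scatter)) moved this assay beyond the scatter, so no step beyond the scatter is expected (a 1.3-fold lower number from compound 3 to compound 4 (0.11 log units; within the scatter)). Compound 4 is estimated at 45000 nM with an expected range from 20000 nM to 90000 nM overall.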

Compound 4, half-maximal inhibitory concentration: 16400 nM
For compound 4 the middle estimate is 2.7-fold (0.44 log units) above the measured one; the whole stated range lies above it.
By their numbers in this assay, from the lowest: compound 4; then compounds 2, 3 and 1 (each within the scatter of the next).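

Exchanging the side chain on this saturated ring carbon moves this assay beyond the scatter, giving modest steps in all three comparisons (a 3.5-fold lower number from compound 3 to compound 4 (0.54 log units; beyond the scatter)) (a 2.1-fold lower number from compound 2 to compound 4 (0.33 log units; beyond the scatter)) (a 3.7-fold lower number from compound 1 to compound 4 (0.57 log units; beyond the scatter)). Compound 1, compound 2 and compound 3, all with a nitrogen on this carbon, stay within the scatter of one another, so (((pyrrolidin-1-yl)methyl)carbonyl)oxy is the only group shown here that separates from them. No measured evidence accounts for the shift.

From the compounds shown here alone, the exchange from compound 3 to compound 4 alters the linking atom and the ring together, so the share of each remains open. An amide bearing pyrrolidin-1-yl, or an ester bearing 4-methylpiperazin-1-yl, would divide the two.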